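The source may report more compounds than this note shows. Statements on the series, on what has been measured and on what is new or still open speak of the compounds shown alone.

Compound 1 `CC1=C(C(C)C(=O)NCCN(C)C)c2cc(F)ccc2/C1=C\c1ccc([S+](C)[O-])cc1`: in a functional assay on MDA-MB-231 cells (Homo sapiens) for inhibition, read by CellTiter-Glo, with a stated time of 96 h (on this read-out lower numbers stand for higher toxicity in this test and higher numbers for lower toxicity in this test), compound 1 gives > 50000 nM, which is a limit of the assay.
Compound 2 `CC1=C(C(C)C(=O)NCCN2CCCC2)c2cc(F)ccc2/C1=C\c1ccc([S+](C)[O-])cc1`: in this assay compound 2 gives 39300 nM.
Compound 3 `CC1=C(C(C)C(=O)N2CCN(CCN(C)C)CC2)c2cc(F)ccc2/C1=C\c1ccc([S+](C)[O-])cc1`: in this assay compound 3 gives > 50000 nM, again a limit of the assay.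

Compound 3 therefore stands at the limit of > 50000 nM in this assay, at which 2 of the 3 values shown sit, so its position relative to the others is only loosely fixed: the steps a step that the two limits leave unreadable from compound 1 to compound 3 and an at least 1.2-fold higher number from compound 2 to compound 3 (0.10 log units; that floor lies within the scatter) say little. Compound 4 `CC1=C(C(C)C(=O)N2CCN(c3ccncc3)CC2)c2cc(F)ccc2/C1=C\c1ccc([S+](C)[O-])cc1` differs from compound 3 by pyridin-4-yl in place of 2-(dimethylamino)ethyl on an amine nitrogen in a ring. Going by the values given here, no measured step alters this part of the molecule; the steps of an at least 1.2-fold lower number from compound 1 to compound 2 (0.10 log units; that floor lies within the scatter) and an at least 1.2-fold higher number from compound 2 to compound 3 (0.10 log units; that floor lies within the scatter) concern the amide side only and stay within the scatter. No step beyond the scatter is therefore expected in this assay. Compound 4 is estimated at 50000 nM, in the range 20000 nM to 100000 nM. This estimate means a step of a number no higher from compound 3 to compound 4 (the limit leaves the size open) is expected.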

Compound 4, half-maximal cytotoxic concentration: 19600 nM
Compound 4: middle estimate off by 2.6-fold (0.41 log units), on the high side; the measured number lies below the stated range.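

In this assay, going by these compounds alone, pyridin-4-yl on this amine nitrogen gives an at least 2.5-fold lower number from compound 3 to compound 4 (0.40 log units; beyond the scatter) as the first step beyond the scatter. Against the (2-(dimethylamino)ethyl)amino group the picture is the same, with an at least 2.5-fold lower number from compound 1 to compound 4 (0.40 log units; beyond the scatter) as its step, whereas a 2.0-fold lower number from compound 2 to compound 4 (0.30 log units; within the scatter) stays within the scatter, so compound 4 is not set apart from compound 2. On these data alone, the two steps beyond the scatter are only floors, since their true size stays open: the limit of > 50000 nM in this assay, at which 2 of the 4 values shown sit.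

As far as these compounds go, whether plain phenyl or pyridin-3-yl on the same nitrogen would give a similar number stays open. So does the effect of a small group such as methyl there.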